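The source may hold more compounds than are shown below. What is called first, only, known or untested is meant among the compounds shown, and "the series" means these compounds.

Among the three compounds examined in an assay on cells for inhibition of Voltage-dependent L-type calcium channel subunit alpha-1C (Homo sapiens), read by FLIPR and calcium flux, tested at 3 uM (on this read-out lower numbers stand for a weaker effect and higher numbers for a stronger effect at the one concentration tested), compound 3 `CS(=O)(=O)c1ccccc1C(=O)N1CCC(N(C2CC2)S(=O)(=O)c2cccc(C(F)(F)F)c2)CC1` stands highest with 39%. Compound 2 `NC(=O)c1ccc(C(=O)N2CCC(N(C3CC3)S(=O)(=O)c3cccc(C(F)(F)F)c3)CC2)cc1` gives 0%, and the step of a number 39 percentage points higher from compound 2 to compound 3 (beyond the scatter) is the only one measured. Compound 1 `COC(=O)c1cccc(C(=O)N2CCC(N(C3CC3)S(=O)(=O)c3cccc(C(F)(F)F)c3)CC2)c1` has "not determined" (no result reported), so it adds nothing to the comparison.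

The next compound, compound 4 `O=C(c1cccc(OC(F)(F)F)c1)N1CCC(N(C2CC2)S(=O)(=O)c2cccc(C(F)(F)F)c2)CC1`, changes a different part of compound 3: 3-(trifluoromethoxy)phenyl in place of 2-(methylsulfonyl)phenyl on a carbonyl carbon. Among the measured compounds shown here, no measured step covers this swap; the one known step concerns another pair of groups, so it bears only loosely on what follows. A modest move in either direction, or none beyond the scatter, seems equally possible for compound 4, and the expected step is a number 14 percentage points lower from compound 3 to compound 4 (beyond the scatter). On balance compound 4 is estimated at 25%, within a range from 0% to 55%.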

Compound 4, a percentage reported as inhibition, at one concentration (the size of the read-out at that concentration, not a potency): 78%
Beside the measured number, compound 4's estimate is 53 percentage points below it; measured number outside the range, above it.
By their numbers in this assay, from the lowest: compound 2; then compound 3; then compound 4.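

The group on the carbonyl carbon can by itself carry a large change in this assay with the rest of the molecule held fixed. Putting 3-(trifluoromethoxy)phenyl in place of 2-(methylsulfonyl)phenyl gives a number 39 percentage points higher from compound 3 to compound 4 (beyond the scatter) and putting it in place of 4-carbamoylphenyl gives a number 78 percentage points higher from compound 2 to compound 4 (beyond the scatter). No measurement shown explains this change. The compounds shown do not separate the effect of the trifluoromethoxy group from that of its place on the ring. A plain phenyl or a 3-chlorophenyl on the same carbonyl carbon would help to tell these apart.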